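One Added Methoxy Group and a Cytotoxicity Estimate

The source may report more compounds than this note shows. Statements on the series, on what has been measured and on what is new or still open speak of the compounds shown alone.

Compound 1 `COc1ccc(-c2nc3cc(C(C)O)ccc3[nH]2)c(OC)c1` gives > 100000 nM as a limit of the assay
Compound 2 `COc1ccc(-c2nc3cc(/C(C)=N/NC(N)=O)ccc3[nH]2)cc1` gives 25000 nM as a measured number

Within the data shown here, in an ADME assay on MDBK cells (Bos taurus) for cytotoxicity, read by MTT assay, with a stated time of 96 h (on this read-out lower numbers stand for higher toxicity in this test and higher numbers for lower toxicity in this test), compound 2 gives 25000 nM as the only true number so far. Compound 1 reads > 100000 nM and that is a limit. Compound 3 `COc1ccc(-c2nc3cc(/C(C)=N/NC(N)=O)ccc3[nH]2)c(OC)c1` is compound 2 with one change methoxy in place of hydrogen on an aromatic carbon that puts methoxy in place of hydrogen on an aromatic carbon, ortho to a large group. Among the measured compounds shown here, no step between measured compounds differing in one place is available to size this change. Compound 1 carries both methoxy groups of compound 3 but differs elsewhere too. In this assay no shift beyond the scatter is expected, with only a slight lean toward lower toxicity in this test. The estimated 1.3-fold higher number from compound 2 to compound 3 (0.11 log units; within the scatter) is expected to stay small. Compound 3 is estimated at 32000 nM with an expected range from 11000 nM to 90000 nM once it is measured.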

Compound 3, half-maximal cytotoxic concentration: > 100000 nM
Compound 3 gave a limit, no number; the forecaster's own chance of this, stated with the estimate: 10%; at least 3.1-fold (0.49 log units) between middle value and limit.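

In this assay, methoxy in place of hydrogen on an aromatic carbon, ortho to a large group, gives an at least 4.0-fold higher number from compound 2 to compound 3 (0.60 log units; beyond the scatter), so this place on the ring responds to a single small change beyond the scatter. Compound 1 carries the same two methoxy groups but differs elsewhere too, so it could not show this. The full size of the change remains unknown and the step between the two limit-bearing compounds cannot be read, since compound 3 and compound 1 both read only as limits: the limit of > 100000 nM in this assay, at which 2 of the 3 values shown sit.

From the compounds shown here alone, it remains open how a fluorine, an ethoxy group or an amine at this same place would compare with methoxy. Going by these compounds, it also remains open whether the new methoxy group would give a similar step without the methoxy group already on the ring.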